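A few compounds are considered here, and "the series" means these few. Any claim that something is new, unique, unknown or untested is made for them only; others in the source may bear on it.

Three compounds have been measured in an assay on HEK293 cells for inhibition of Voltage-dependent T-type calcium channel subunit alpha-1G (Homo sapiens); on this read-out lower numbers stand for stronger inhibition and higher numbers for weaker inhibition:
compound 1 `COC(=O)CC1c2ccccc2N=C(Nc2ccccc2)N1CCCCCNC(=O)OC(C)(C)C` with 2270 nM,
compound 2 `CC(C)(C)OC(=O)NCCCCCN1C(Nc2ccccc2)=Nc2ccccc2C1CC(=O)NCc1ccccc1` with 1200 nM,
compound 3 `COC(=O)CC1c2ccccc2N=C(NCCCCCN)N1c1ccccc1` with 1840 nM.

Compound 2 differs from compound 1 by a single change, (benzylamino in place of methoxy on a carbonyl carbon), and this change brought a 1.9-fold lower number from compound 1 to compound 2 (0.28 log units; within the scatter) in this assay. Compound 4 `NCCCCCNC1=Nc2ccccc2C(CC(=O)NCc2ccccc2)N1c1ccccc1` has not yet been measured. It arises from compound 3 by the same change, (benzylamino in place of methoxy on a carbonyl carbon), at a place described in the same words as before. The difference between the core of compound 1 and the core of compound 3 is not broken down here; their two values in this assay lie within the scatter of each other. Resting on a 1.9-fold lower number from compound 1 to compound 2 (0.28 log units; within the scatter), compound 4 is expected to show a 1.8-fold lower number from compound 3 to compound 4 (0.26 log units; within the scatter). Compound 4 is therefore estimated at 1000 nM, with a likely range from 450 nM to 2200 nM.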

Compound 4, half-maximal inhibitory concentration: 3130 nM
Beside the measured number, compound 4's estimate is 3.1-fold (0.50 log units) below it, outside the stated range (above it).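

In this assay, benzylamino in place of methoxy on a carbonyl carbon brought a 1.7-fold higher number from compound 3 to compound 4 (0.23 log units; within the scatter). Set beside the earlier step, this shows that the change did not carry over as a constant increment from the core of compound 1 to the core of compound 3: the same change on two cores in this assay, a 1.9-fold lower number (0.28 log units; within the scatter) from compound 1 to compound 2 and a 1.7-fold higher number (0.23 log units; within the scatter) from compound 3 to compound 4, 3.2-fold (0.51 log units) apart, beyond the scatter of two such steps. Each step on its own remains within the scatter, and these two pairs neither identify which difference between the cores matters nor give a rule for other cores.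

The compounds shown leave open whether a carboxylic acid or a methylamino group on that carbonyl carbon would follow either step. They also leave open whether a shorter chain would change the gap between the two steps.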